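A few compounds are considered here, and "the series" means these few. Any claim that something is new, unique, unknown or untested is made for them only; others in the source may bear on it.

Within the data shown here, compound 2 `CCOC(=O)c1oc2ccc(NS(=O)(=O)c3cccc(Cl)c3)cc2c1C` stands at the higher of the two numbers so far in a functional assay on MDA-MB-231 cells (Homo sapiens) for antiproliferative activity, read by MTT assay, with a stated time of 72 h (a higher number here means a weaker inhibitor, a lower number a stronger inhibitor), where compound 2 gives 57300 nM. Among the measured compounds shown here, its only neighbour is compound 1 `CCOC(=O)c1oc2ccc(NS(=O)(=O)c3ccc(Cl)cc3)cc2c1C`, which in this assay gives 53900 nM; the step of a 1.1-fold higher number from compound 1 to compound 2 (0.03 log units; within the scatter) shows that moving the chloro substituent on the phenyl attached to the sulfonyl sulfur made no difference beyond the scatter. Compound 3 `CCOC(=O)c1oc2ccc(NS(=O)(=O)c3cccc([N+](=O)[O-])c3)cc2c1C` differs from compound 2 in one place: nitro in place of chloro on an aromatic carbon. For the measured compounds named here, no measured step bears directly on swapping chloro for nitro; the single step in hand, a 1.1-fold higher number from compound 1 to compound 2 (0.03 log units; within the scatter), concerns a different change and was flat. With nothing to point either way, the expected step of a 1.0-fold lower number from compound 2 to compound 3 (0.02 log units; within the scatter) is small, and compound 3 is estimated to give 55000 nM in this assay, within a range from 15000 nM to 200000 nM.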

Compound 3, half-maximal inhibitory concentration: 59900 nM
Compound 3: the middle estimate sits 1.1-fold (0.04 log units) below what was measured; measured number inside the range.
By their numbers in this assay, from the lowest: compounds 1, 2 and 3 (each within the scatter of the next).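

In this assay, the change from chloro to nitro on this aromatic carbon gives a 1.0-fold higher number from compound 2 to compound 3 (0.02 log units; within the scatter), so a group of three heavy atoms stands here in place of one with no difference beyond the scatter. The comparison with the 4-chlorophenyl compound gives a 1.1-fold higher number from compound 1 to compound 3 (0.05 log units; within the scatter), so replacing that group with 3-nitrophenyl also makes no difference beyond the scatter, and the three compounds cannot be told apart in this assay. There is no evidence on why these changes leave the number flat.

As far as these compounds go, whether an amine or a carboxylic acid on this aromatic carbon would move the number remains open. Also open, from the compounds shown here alone, is whether a change elsewhere on the shared core would move it more than these changes on the phenyl did.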